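Swapping a cyclopentyl chain for a dimethylbenzyl group

This account rests on a few compounds, and the source may have more. Where it says the series, first, only, none or still open, it means among the compounds named here.

Among the compounds with values here, in a functional assay on Jurkat cells (Homo sapiens) (on this read-out lower numbers stand for stronger inhibition and higher numbers for weaker inhibition), compound 1 `C[C@H](NC(=O)C(=O)NCCC1CCCC1)C(=O)N[C@@H](CC(=O)O)C(=O)COc1c(F)c(F)cc(F)c1F` gives 11 nM, the lowest of the three numbers measured so far. Compound 2 `C[C@H](NC(=O)C(=O)Nc1cccnc1N(C)C)C(=O)N[C@@H](CC(=O)O)C(=O)COc1c(F)c(F)cc(F)c1F` follows in this assay with 27 nM, and compound 3 `C[C@H](NC(=O)C(=O)NCc1ccc(F)cc1)C(=O)N[C@@H](CC(=O)O)C(=O)COc1c(F)c(F)cc(F)c1F` gives 197 nM. The step of a 2.5-fold higher number from compound 1 to compound 2 (0.39 log units; beyond the scatter) is the smaller of the two departures from compound 1, whereas an 18-fold higher number from compound 1 to compound 3 (1.25 log units; beyond the scatter) is the larger, and a 7.3-fold higher number from compound 2 to compound 3 (0.86 log units; beyond the scatter) separates the two alternatives from each other.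

Compound 4 `Cc1cccc(CNC(=O)C(=O)N[C@@H](C)C(=O)N[C@@H](CC(=O)O)C(=O)COc2c(F)c(F)cc(F)c2F)c1C` has not yet been measured in this assay. Compared with compound 1 it carries the following change: 2,3-dimethylphenyl in place of cyclopentylmethyl on a saturated chain carbon bound to an amide-type nitrogen. The step that bears most directly on it is an 18-fold higher number from compound 1 to compound 3 (1.25 log units; beyond the scatter), where an aromatic ring likewise replaced the cyclopentylmethyl group on the saturated chain carbon bound to the amide-type nitrogen. Within the data shown here, no measured step shows how a 2,3-dimethylphenyl ring differs from a 4-fluorophenyl ring in this position. On this basis the step for compound 4 is expected to be a rise of roughly a 7.3-fold higher number from compound 1 to compound 4 (0.86 log units; beyond the scatter). Compound 4 is therefore estimated at about 80 nM, with a plausible range from 20 nM to 320 nM.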

Compound 4, half-maximal inhibitory concentration: 102 nM
For compound 4 the middle estimate is 1.3-fold (0.11 log units) below the measured one; the range from low to high includes it.
By their numbers in this assay, from the lowest: compound 1; then compound 2; then compounds 4 and 3 (each within the scatter of the next).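

In this assay, a second benzyl-type amide also falls well short of the 2-cyclopentylethyl amide (a 9.3-fold higher number from compound 1 to compound 4 (0.97 log units; beyond the scatter)), so the loss seen with compound 3 is not confined to the 4-fluorophenyl ring. Replacing 4-fluorophenyl with 2,3-dimethylphenyl on this saturated chain carbon makes no difference that can be separated from the scatter (a 1.9-fold lower number from compound 3 to compound 4 (0.29 log units; within the scatter)). Compound 2 also keeps a lower number than compound 4 (a 3.8-fold higher number from compound 2 to compound 4 (0.58 log units; beyond the scatter)), and no available measurement explains any of these differences.

Both benzyl amides change the ring and shorten the chain in one step, so the contribution of each remains unresolved. On these data alone, a 2-phenylethyl or cyclopentylmethyl group on the amide nitrogen would separate the two, while an amine or a carboxylic acid on the phenyl ring remains unexplored.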